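The source may report more compounds than this note shows. Statements on the series, on what has been measured and on what is new or still open speak of the compounds shown alone.

Compound 1, `Fc1ccccc1Nc1nc2nonc2nc1Nc1ccccc1`, gives 2200 nM in an assay on mitochondria from L6 cells (Rattus norvegicus) for activation, with a stated time of 90 min; a higher number here means that more compound is needed for the effect, a lower number that less compound is needed. Compound 2, `Fc1ccccc1Nc1nc2nonc2nc1NCCC(F)(F)F`, gives in this assay only a limit of the assay, > 100000 nM.

Compound 2 therefore stands at the weak end of the two measured compounds, sitting at the limit of > 100000 nM in this assay, at which 1 of the 2 values shown sits, after the step of an at least 45-fold higher number from compound 1 to compound 2 (1.65 log units; beyond the scatter). Compound 3, `Fc1ccccc1Nc1nc2nonc2nc1NC1CCCCC1`, differs from compound 2 in one place: cyclohexyl in place of 3,3,3-trifluoropropyl on a nitrogen on an aromatic ring. Among the compounds with values here, only that one measured step bears on this change, and it shows that exchanging phenyl for 3,3,3-trifluoropropyl on this nitrogen costs a great deal. Cyclohexyl, a six-membered non-aromatic ring of carbon only, brings a ring back to the nitrogen, though not the phenyl of compound 1, so a lower number in this assay is expected for compound 3, while the limit for compound 2 leaves its size uncertain. Compound 3 is expected to give 30000 nM, with a range from 5000 nM to 200000 nM. The step of an at least 3.3-fold lower number from compound 2 to compound 3 (0.52 log units; beyond the scatter) is the expected outcome.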

Compound 3, half-maximal effective concentration: 13400 nM
Estimate against measurement, compound 3: 2.2-fold (0.35 log units) above; the measured number falls inside the stated range.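

On this nitrogen in this assay, cyclohexyl gives an at least 7.4-fold lower number from compound 2 to compound 3 (0.87 log units; beyond the scatter), so an all-carbon non-aromatic ring recovers part of what was lost with 3,3,3-trifluoropropyl. It does not recover all of it, since the comparison with phenyl shows a 6.1-fold higher number from compound 1 to compound 3 (0.78 log units; beyond the scatter), which places phenyl ahead of cyclohexyl at this position and shows that a ring alone does not match the phenyl of compound 1. From the compounds shown here alone, the value for compound 2 is only a limit of the assay, so the full size of the gain remains unknown: the limit of > 100000 nM in this assay, at which 1 of the 3 values shown sits.

Going by these compounds, what remains open is whether the poor result of compound 2 comes from the open chain or from its fluorine atoms, a question that a plain propyl chain on this nitrogen would address. Also open, on these data alone, is how a benzyl group or a smaller cyclopentyl ring would compare with phenyl and cyclohexyl.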